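A few compounds are considered here, and "the series" means these few. Any claim that something is new, unique, unknown or untested is made for them only; others in the source may bear on it.

Compound 2 `CCCCCCCCCCCCCCCOC(=O)CCC(=O)N1CCN(CCCOc2cc3c(Nc4ccc(F)c(Cl)c4)ncnc3cc2OC)CC1` is the ester with the longer chain among the two compounds measured in a functional assay on A549 cells (Homo sapiens) for cytotoxicity, read by MTT assay, with a stated time of 24 h, tested at 60 uM (a lower number here means a stronger effect, a higher number a weaker effect of the compound at the concentration tested), and in that assay compound 2 gives 81.6%. That is the highest of the two numbers; its nearest neighbour is compound 1 `CCCCCCCCOC(=O)CCC(=O)N1CCN(CCCOc2cc3c(Nc4ccc(F)c(Cl)c4)ncnc3cc2OC)CC1`, which in this assay gives 26%. For the measured compounds named here, the one step between measured compounds is the lengthening of the ester chain, and it was large: a number 55.6 percentage points higher from compound 1 to compound 2 (beyond the scatter). Compound 3 `CCCCCCCCCCCCCCCCCOC(=O)CCC(=O)N1CCN(CCCOc2cc3c(Nc4ccc(F)c(Cl)c4)ncnc3cc2OC)CC1` carries the same change a little further: ethyl in place of hydrogen on a saturated chain carbon, ten or more bonds along the chain from an oxygen next to a carbonyl group. Going by the values given here, the only step that bears on it, the one from compound 1 to compound 2, points upward, but it added heptyl, whereas here only ethyl enters, and the number for compound 2 already stands well toward the upper end of what this read-out can report. For compound 3 a further rise is therefore expected, but a smaller one, estimated as a number 6.4 percentage points higher from compound 2 to compound 3 (within the scatter). In this assay compound 3 is expected to give about 88%, with the likely range from 72% to 100%.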

Compound 3, a percentage reported as activity, at one concentration (the size of the read-out at that concentration, not a potency): 84.1%
For compound 3 the middle estimate is 3.9 percentage points above the measured one; low and high end bracket the measured number.
By their numbers in this assay, from the lowest: compound 1; then compounds 2 and 3 (each within the scatter of the next).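

In this assay, ethyl in place of hydrogen on a saturated chain carbon, ten or more bonds along the chain from an oxygen next to a carbonyl group, gives a number 2.5 percentage points higher from compound 2 to compound 3 (within the scatter), so the two longest chains cannot be told apart here. The full extension of the chain gives a number 58.1 percentage points higher from compound 1 to compound 3 (beyond the scatter), and the large rise thus already stands in the heptyl step and is not visibly carried further by the added ethyl. Nothing available explains why the read-out responds to chain length in this way.

The compounds shown leave open how an ester with a chain of intermediate length would read, and with it where along the chain the large step sets in. They also leave open how a shorter chain, or a carboxylic acid in place of the ester, would read in this assay.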